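Replacing the Aryl on the Ring Nitrogen with a Propyl-Linked Aryl

The source may report more compounds than this note shows. Statements on the series, on what has been measured and on what is new or still open speak of the compounds shown alone.

Of the compounds shown here, three sharing one core have been measured in a functional assay on CHO cells with adenosine receptor A1 (Homo sapiens) as the target, read by cAMP accumulation and immunoassay, with a stated time of 6 min, tested at 0.01 uM; on this read-out lower numbers stand for a stronger effect and higher numbers for a weaker effect at the one concentration tested. Compound 1 `COc1ccc(N2CCN(Cc3csc(N)c3C(=O)c3ccc(Cl)cc3)CC2)cc1` gives -1.2%, compound 2 `Nc1scc(CN2CCN(c3ccc(OC(F)(F)F)cc3)CC2)c1C(=O)c1ccc(Cl)cc1` gives 0%, and compound 3 `Nc1scc(CN2CCN(c3cc(F)cc(F)c3)CC2)c1C(=O)c1ccc(Cl)cc1` gives -13%. Compound 3 holds the lowest of the three numbers: the step of a number 11.8 percentage points lower from compound 1 to compound 3 (beyond the scatter) and the step of a number 13 percentage points lower from compound 2 to compound 3 (beyond the scatter) both lie beyond the scatter, whereas the step of a number 1.2 percentage points higher from compound 1 to compound 2 (within the scatter) does not.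

Compound 4 `Nc1scc(CN2CCN(CCCc3ccc(Cl)cc3)CC2)c1C(=O)c1ccc(Cl)cc1` differs from compound 3 in one place: 3-(4-chlorophenyl)propyl in place of 3,5-difluorophenyl on an amine nitrogen in a ring. For the measured compounds named here, none of the measured steps carries the same kind of change. The two steps that reach compound 3 swap one aromatic substituent on the amine nitrogen in a ring for another, and they are modest in size; the step from compound 1 to compound 2 changes only a group on an oxygen and stays within the scatter. Since the change from compound 3 to compound 4 exchanges an aromatic group for a 3-(4-chlorophenyl)propyl chain on the same nitrogen, and since all three measured numbers sit near zero, the expected step of a number 8 percentage points higher from compound 3 to compound 4 (within the scatter) is a small one, most likely back toward the values of compound 1 and compound 2. Compound 4 is therefore estimated at -5%, within a range of -20% to 10%.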

Compound 4, a percentage reported as activity, at one concentration (the size of the read-out at that concentration, not a potency): 0%
Compound 4: the middle estimate sits 5 percentage points below what was measured; low and high end bracket the measured number.
By their numbers in this assay, from the lowest: compound 3; then compounds 1, 2 and 4 (each within the scatter of the next).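

In this assay, the step of a number 13 percentage points higher from compound 3 to compound 4 (beyond the scatter) shows that the lower number of compound 3 does not carry over when 3-(4-chlorophenyl)propyl takes the place of 3,5-difluorophenyl on the amine nitrogen in a ring. For the compounds shown here, the steps of no change at the digits printed from compound 2 to compound 4 (within the scatter) and a number 1.2 percentage points higher from compound 1 to compound 4 (within the scatter) show that this propyl-linked aryl cannot be told apart from 4-(trifluoromethoxy)phenyl or 4-methoxyphenyl at this position, so among the four compounds only the one carrying 3,5-difluorophenyl stands apart, and a propyl chain between the nitrogen and the aromatic ring does not by itself separate compound 4 from compounds 1 and 2. Nothing available explains why the number moves at this position.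

Because the change to compound 4 alters the chain and the ring substituents together, the compounds shown cannot say which of the two accounts for the step, a question that a 3-(3,5-difluorophenyl)propyl group on the same nitrogen would address. They also leave open how a shorter ethyl chain, or a carbonyl joining the aromatic ring to that nitrogen, would read at this one concentration.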